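Three limits and one new phenyl group

The compounds below may be only part of what the source reports. "The series", "measured", "known", "first", "only" and "open" are said of these compounds alone.

- compound 1 `Nc1nc(NCCNc2ncc(-c3ncc[nH]3)c(-c3cc(F)c(F)cc3F)n2)ccc1[N+](=O)[O-]` gives > 0.5 h as a limit
- compound 2 `Nc1nc(NCCNc2ncc(-c3ncc[nH]3)c(-c3ccc(F)cc3Cl)n2)ccc1[N+](=O)[O-]` gives > 0.5 h as a limit
- compound 3 `Nc1nc(NCCNc2ncc(-c3ncc[nH]3)c(-c3ccc(F)cc3C(F)(F)F)n2)ccc1[N+](=O)[O-]` gives > 0.5 h as a limit

In an ADME assay on microsomes from liver (Rattus norvegicus) for metabolic stability (on this read-out lower numbers stand for a shorter-lived compound and higher numbers for a longer-lived compound), compound 3 gives > 0.5 h and this is a limit, not a number. The other two readings are limits too: the limit of > 0.5 h in this assay, at which 3 of the 3 values shown sit, and no true number is known for any of them.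

The unmeasured compound 4 `Nc1nc(NCCNc2ncc(-c3ncc[nH]3)c(-c3cc(F)c(Cl)cc3F)n2)ccc1[N+](=O)[O-]` differs from compound 3 in one group (4-chloro-2,5-difluorophenyl in place of 4-fluoro-2-(trifluoromethyl)phenyl on an aromatic carbon) with 4-chloro-2,5-difluorophenyl in place of 4-fluoro-2-(trifluoromethyl)phenyl.

The swaps at this same place are the closest guide: a step that the two limits leave unreadable from compound 1 to compound 2 then a step that the two limits leave unreadable from compound 1 to compound 3 and a step that the two limits leave unreadable from compound 2 to compound 3 and none of them shows a size. The expected step is a step that the limit leaves unreadable from compound 3 to compound 4 and it is expected to stay within the scatter, with no direction foreseen. For compound 4 the estimate in this assay is 0.8 h with an expected range from 0.4 h to 1.6 h if a number is reported at all.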

Compound 4, half-life: > 0.5 h
Compound 4 ended at the assay's limit; the forecaster's own chance of this, stated with the estimate: 85%; the middle value is on the limit's open side.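

Among the compounds shown here, compound 4 joins compound 1, compound 2 and compound 3 at a limit, so no step among them can be read: the limit of > 0.5 h in this assay, at which 4 of the 4 values shown sit. In this assay the true half-lives of these compounds stay open, as does whether their phenyl groups make any difference.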